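Naphthalenesulfonamide series: lactam replaced by dimethylaminomethyl

The source may hold more compounds than are shown below. What is called first, only, known or untested is meant among the compounds shown, and "the series" means these compounds.

Measured so far:
compound 1 `Cc1noc(NS(=O)(=O)c2cccc3c(N4CCCCC4=O)cccc23)c1C`: 270 nM
compound 2 `Cc1onc(NS(=O)(=O)c2cccc3c(N(C)C)cccc23)c1C`: 60 nM

In an assay on VSM-A10 cells for antagonist activity at Endothelin-1 receptor (Rattus norvegicus) (on this read-out higher numbers stand for weaker inhibition and lower numbers for stronger inhibition), compound 1 gives the higher of the two numbers; compound 2 sits at a lower number, and that gap lies beyond the usual scatter. Among the compounds with values here, no step between the two measured compounds is available, so only the values themselves are compared.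

Compound 3 `Cc1noc(NS(=O)(=O)c2cccc3c(CN(C)C)cccc23)c1C` has not been measured in this assay. Its change from compound 1 is (dimethylamino)methyl in place of 2-oxopiperidin-1-yl on an aromatic carbon. Compound 3 is expected to show a modest step toward a lower number, namely a 2.5-fold lower number from compound 1 to compound 3 (0.39 log units; beyond the scatter), as the values of compound 2 at 60 nM already show a lower number for this core. The estimate for compound 3 in this assay is 110 nM, with a range from 35 nM to 350 nM.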

Compound 3, half-maximal inhibitory concentration: 2800 nM
Compound 3: middle estimate off by 25-fold (1.41 log units), on the low side; the whole stated range lies below it.
By their numbers in this assay, from the lowest: compound 2; then compound 1; then compound 3.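

In this assay, within the data shown here, (dimethylamino)methyl in place of 2-oxopiperidin-1-yl on this aromatic carbon gives a 10-fold higher number from compound 1 to compound 3 (1.02 log units; beyond the scatter), the only single-place comparison so far. This position is therefore sensitive to the group it carries, and this open-chain group cannot stand in for the ring without a large shift toward weaker inhibition. Nothing at hand accounts for the size of this step.

Still open, on these data alone, is whether the step follows the ring, the carbonyl or the attachment to the aromatic carbon. A piperidin-1-yl group without the carbonyl, on the same carbon, would separate the first two.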